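The compounds below may be only part of what the source reports. "The series", "measured", "known", "first", "only" and "open" are said of these compounds alone.

Measured in a functional assay on MCF7 cells (Homo sapiens) for inhibition, read by MTT assay, with stated times of 18 h and 4 h; on this read-out lower numbers stand for stronger inhibition and higher numbers for weaker inhibition:
- compound 1 `CCCOP(=O)(O)OCCSC(=S)N1CCCCC1`: > 100000 nM
- compound 2 `CCCCCCCCOP(=O)(O)OCCSC(=S)N1CCCCC1`: 26000 nM

The value of compound 1, > 100000 nM, is a limit of the assay, not a number. Compound 3 `CCCOP(=O)(O)OCCSC(=S)N1CCCC1` has pyrrolidin-1-yl in place of piperidin-1-yl on a thiocarbonyl carbon. Among the compounds with values here, the only measured step, an at least 3.8-fold lower number from compound 1 to compound 2 (0.58 log units; beyond the scatter), changes the chain and leaves this ring untouched, so it gives no direct size for the swap. Compound 3 keeps the chain of compound 1, and no step beyond the scatter is expected: a step that the limit leaves unreadable from compound 1 to compound 3. For compound 3 the expected value is 120000 nM, with an estimated range of 50000 nM to 300000 nM.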

Compound 3, half-maximal inhibitory concentration: 73000 nM
Beside the measured number, compound 3's estimate is 1.6-fold (0.22 log units) above it; the measured number falls inside the stated range.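

In this assay, within the data shown here, the first change to the ring rather than the chain, pyrrolidin-1-yl in place of piperidin-1-yl on a thiocarbonyl carbon, gives an at least 1.3-fold lower number from compound 1 to compound 3 (0.13 log units; that floor lies within the scatter). Compound 3 therefore provides a measured number with the chain of compound 1, and the smaller ring does not cost measurable activity. Compound 1 stands at a limit of the assay, not a number, so the true size of this step stays unknown: the limit of > 100000 nM in this assay, at which 1 of the 3 values shown sits.

From the compounds shown here alone, whether pyrrolidin-1-yl would act the same way on the longer chain of compound 2 remains open. So does the effect of a morpholin-4-yl ring or an open-chain diethylamino group on this carbon.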